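The source may report more compounds than this note shows. Statements on the series, on what has been measured and on what is new or still open speak of the compounds shown alone.

Working notes on the series. Within the data shown here, compound 2 `COc1cc(N2C(=O)[C@@H](Oc3ccccc3)[C@H]2c2ccc(SC)cc2)cc(OC)c1OC` gives 7700 nM in a functional assay on MCF7 cells (Homo sapiens) for antiproliferative activity, read by MTT assay, with stated times of 24 h and 72 h (on this read-out lower numbers stand for stronger inhibition and higher numbers for weaker inhibition), the second highest of the three numbers known. Among the measured compounds shown here, compound 1 `COc1ccc([C@@H]2[C@@H](Oc3ccccc3)C(=O)N2c2cc(OC)c(OC)c(OC)c2)cc1` gives 6900 nM, a gap to compound 2 within the scatter; compound 3 `CCOC(=O)/C=C/c1ccc([C@@H]2[C@H](Oc3ccccc3)C(=O)N2c2cc(OC)c(OC)c(OC)c2)cc1` gives 87000 nM, a step of an 11-fold higher number from compound 2 to compound 3 (1.05 log units; beyond the scatter), the one large change in the set, and it sits on the same aromatic carbon that the change toward compound 4 involves. Compound 4 `COc1ccc([C@@H]2[C@H](Oc3ccccc3)C(=O)N2c2cc(OC)c(OC)c(OC)c2)c(N)c1O` differs from compound 2 as follows: a group of 10 heavy atoms (7 carbon, 1 nitrogen, 2 oxygen; one six-membered aromatic ring of carbon only) in place of a group of 8 heavy atoms (7 carbon, 1 sulfur; one six-membered aromatic ring of carbon only), on a saturated ring carbon. For the measured compounds named here, no measured step covers the entering group; compound 3 shows only that a replacement of methylsulfanyl here can weaken inhibition strongly. The expected step is therefore a 1.6-fold higher number from compound 2 to compound 4 (0.19 log units; within the scatter), a modest rise and not a large one. Compound 4 is estimated at 12000 nM, within 3500 nM to 45000 nM.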

Compound 4, half-maximal inhibitory concentration: 19000 nM
Compound 4: middle estimate off by 1.6-fold (0.20 log units), on the low side; low and high end bracket the measured number.
By their numbers in this assay, from the lowest: compounds 1 and 2 (each within the scatter of the next); then compound 4; then compound 3.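

In this assay, exchanging the whole aromatic group on the saturated ring carbon gives a 2.5-fold higher number from compound 2 to compound 4 (0.39 log units; beyond the scatter), a modest step beyond the scatter. Unlike the large step of an 11-fold higher number from compound 2 to compound 3 (1.05 log units; beyond the scatter), this shows that an aromatic group carrying hydrogen-bond donors at this position weakens inhibition only modestly. Nothing at hand explains the rise.

The compounds shown do not separate the contributions of the nitrogen and oxygen atoms in the entering group. From the compounds shown here alone, how a carboxylic acid or a longer alkoxy chain on this aromatic ring would read remains open.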